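The compounds below may be only part of what the source reports. "The series", "measured", "known", "first", "only" and "open" are said of these compounds alone.

Measured in a functional assay on HepG2 cells (Homo sapiens) for antiproliferative activity, read by MTT assay, with a stated time of 72 h; a higher number here means a weaker inhibitor, a lower number a stronger inhibitor:
- Compound 1 `COc1ccc(CCc2ccccn2)cc1OC`: 13800 nM
- Compound 2 `COc1cc(CCc2ccc(Br)cc2)cc(OC)c1O`: 8490 nM

A lower number marks a stronger inhibitor, but these two numbers lie within the scatter of repeated measurements. Compound 2, at 8490 nM, therefore cannot be told apart from compound 1, at 13800 nM. Both compounds sit in the same range, and neither can be ranked above the other.

The next compound, compound 3 `COc1cc(CCc2ccc([N+](=O)[O-])cc2)cc(OC)c1O`, is built directly from compound 2 by a single change: nitro in place of bromo on an aromatic carbon, para to a large group (nitro in place of bromo on an aromatic carbon). Going by the values given here, the data hold no measured pair of compounds that differ in one place, so nothing yet shows how large a single change can be in this assay. Without that guide, the expectation is for no step beyond the scatter and no favoured direction, with the range left wide in both directions. The expected change is a 1.1-fold higher number from compound 2 to compound 3 (0.05 log units; within the scatter). For compound 3 the estimated value is 9500 nM. The expected range for compound 3 runs from 3000 nM to 30000 nM.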

Compound 3, half-maximal inhibitory concentration: 11000 nM
For compound 3 the middle estimate is 1.2-fold (0.06 log units) below the measured one, within the range that was stated.
By their numbers in this assay, from the lowest: compounds 2, 3 and 1 (each within the scatter of the next).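

In this assay, going by these compounds alone, this is the first pair of compounds that differ in one place, and swapping bromo for nitro on an aromatic carbon, para to a large group, gives a 1.3-fold higher number from compound 2 to compound 3 (0.11 log units; within the scatter) and so no step that can be told from ordinary assay noise. This gives the series its first guide to the size of a single change: at this position, nitro brings more heavy atoms and hydrogen-bond acceptors than bromo, yet compound 3 cannot be separated from compound 2. Within the data shown here, the result shows only that this one exchange leaves the number in the same range, and no measurement on hand explains why the two groups read alike.

One exchange between two groups cannot show whether this position tolerates substitution in general, so an amine or a carboxylic acid on the same aromatic carbon might still move the number beyond the scatter. Among these compounds, also open is how much the rest of the shared core matters, since no single-place step yet tests its hydroxy or methoxy groups.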